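The compounds below may be only part of what the source reports. "The series", "measured", "known", "first", "only" and "open" are said of these compounds alone.

Measured so far in an ADME assay for permeability, using PAMPA; on this read-out lower numbers stand for lower permeability and higher numbers for higher permeability:
Compound 1 `CCCC[C@H](NC(=O)[C@H](CCCCN)NC(=O)[C@H](CCCNC(=N)N)NC(=O)c1ccc(/C=C2\SC(=O)N(CCCC)C2=O)cc1)C(N)=O`: 1.18 10^-6 cm/s
Compound 2 `CCCC[C@H](NC(=O)[C@H](CCCCN)NC(=O)[C@H](CCCNC(=N)N)NC(=O)c1cccs1)C(N)=O`: "impermeable" (no number reported), reported without a number
Compound 3 `CCCC[C@H](NC(=O)[C@H](CCCCN)NC(=O)[C@H](CCCNC(=N)N)NC(=O)c1ccc(/C=C2\SC(=S)N(Cc3ccc(OC)cc3)C2=O)cc1)C(N)=O`: 0.6 10^-6 cm/s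

Of the two compounds with a reported number in this assay, compound 3 and compound 1 lie within the scatter of each other, so no order between them can be read from the data. Compound 2 gave no number at all in this assay. Compound 4 `CCCC[C@H](NC(=O)[C@H](CCCCN)NC(=O)[C@H](CCCNC(=N)N)NC(=O)c1ccc(/C=C2\SC(=S)N(c3ccc(OC)cc3)C2=O)cc1)C(N)=O` is not yet measured. It differs from compound 3 in one place: 4-methoxyphenyl in place of 4-methoxybenzyl on an amide-type nitrogen in a ring. Within the data shown here, no step between two measured compounds that differ in only one place is available to calibrate this change, and the three measured compounds differ from each other in more than one place. The change is a small one, so in this assay compound 4 is expected to stay close to compound 3. The expected step of no change at the digits printed from compound 3 to compound 4 (within the scatter) is none beyond the scatter. Compound 4 is estimated at 0.6 10^-6 cm/s, with a range from 0.25 10^-6 cm/s to 1.4 10^-6 cm/s.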

Compound 4, apparent permeability: 0.59 10^-6 cm/s
Compound 4: middle estimate off by 1.0-fold (0.01 log units), on the high side, and the stated range covers the measured number.
By their numbers in this assay, from the lowest: compounds 4, 3 and 1 (each within the scatter of the next).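

In this assay, 4-methoxyphenyl in place of 4-methoxybenzyl on the amide-type nitrogen in the ring gives a 1.0-fold lower number from compound 3 to compound 4 (0.01 log units; within the scatter), the first single-place step available in this series. At this position, the read-out therefore does not separate the two groups, so the methylene link between the nitrogen and the aromatic ring can go without a measurable difference here. No measurement shown accounts for this result.

The compounds shown leave open whether the same holds for a longer chain at this nitrogen, such as 2-(4-methoxyphenyl)ethyl, or for a carboxylic acid or an amine in place of the methoxy group. Among these compounds, the separate contributions of the nitrogen substituent and the ring carbonyl or thiocarbonyl also stay open, with no single-place pair to resolve either.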